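Hydroxy for Fluoro: From Compound 3 to Compound 4

This account rests on a few compounds, and the source may have more. Where it says the series, first, only, none or still open, it means among the compounds named here.

Measured in a functional assay on the whole organism for inhibition, with Rattus norvegicus as the target, in the maximal electroshock model, at a dose of 25 mg/kg by the intraperitoneal route; on this read-out higher numbers stand for more inhibition at the one dose given (going by the name of the read-out) and lower numbers for less inhibition:
- compound 1, `CC(C)N(C)c1ncnc2c1ncn2Cc1ccccc1`: 17%
- compound 2, `CN(c1ncnc2c1ncn2Cc1ccccc1)C1CCCC1`: 17%
- compound 3, `CN(C)c1ncnc2c1ncn2Cc1ccc(F)cc1`: 33%

Compound 3 stands highest of the three, its number lying beyond the scatter above both compound 1 and compound 2. Going by the values given here, the one step between measured compounds, no change at the digits printed from compound 1 to compound 2 (within the scatter), concerns the group on the ring nitrogen and not the six-membered ring, so no measured step bears on the change now made. Compound 4, `CN(C)c1ncnc2c1ncn2Cc1ccc(O)cc1`, differs from compound 3 by hydroxy in place of fluoro on an aromatic carbon. With nothing in the data on hydroxy in place of fluoro on an aromatic carbon, the expectation for compound 4 rests on compound 3 alone, which gives 33%. Compound 4 is therefore expected to show a step of about a number 11 percentage points lower from compound 3 to compound 4 (beyond the scatter), a modest fall at most, with an estimate of 22% and a range from 5% to 40%.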

Compound 4, a percentage reported as inhibition, in the whole organism at one dose (the size of the read-out at that dose, not a potency): 0%
For compound 4 the middle estimate is 22 percentage points above the measured one; the whole stated range lies above it.
By their numbers in this assay, from the lowest: compound 4; then compounds 1 and 2 (each within the scatter of the next); then compound 3.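

In this assay, going by these compounds alone, this position proves able to move the read-out: hydroxy in place of fluoro gives a number 33 percentage points lower from compound 3 to compound 4 (beyond the scatter), whereas the only earlier step concerned the group on the ring nitrogen and stayed within the scatter. An exchange of one heavy atom for another on the aromatic carbon is thus enough for a large step. Nothing measured here accounts for the fall. Going by these compounds, whether methoxy, chloro or an amine at this position would keep the inhibition remains open. So does how fluoro or hydroxy would behave with isopropyl or cyclopentyl on the nitrogen.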